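A few compounds are considered here, and "the series" means these few. Any claim that something is new, unique, unknown or untested is made for them only; others in the source may bear on it.

Compound 1, `Cc1ccc(S(=O)(=O)N(Cc2nc3ccccc3[nH]2)c2ccc(F)cc2)cc1` — 45000 nM
Compound 2, `Cc1ccc(S(=O)(=O)N(Cc2nc3ccccc3[nH]2)c2ccc(Cl)cc2)cc1` — 42200 nM
Compound 3, `Cc1ccc(N(Cc2nc3ccccc3[nH]2)S(=O)(=O)c2ccc(C)cc2)cc1` — 48900 nM

All three share one core and differ only in the group on the ring that carries the nitrogen of the sulfonamide. In a functional assay on PC-3 cells (Homo sapiens) for inhibition, read by MTT assay, with a stated time of 48 h (on this read-out lower numbers stand for stronger inhibition and higher numbers for weaker inhibition), compound 3 sits together with the other two: the step of a 1.1-fold higher number from compound 1 to compound 3 (0.04 log units; within the scatter) and the step of a 1.2-fold higher number from compound 2 to compound 3 (0.06 log units; within the scatter) both stay within the scatter, as does the step of a 1.1-fold lower number from compound 1 to compound 2 (0.03 log units; within the scatter) between the halogens. Nothing separates the three.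

Compound 4, `COc1ccc(N(Cc2nc3ccccc3[nH]2)S(=O)(=O)c2ccc(C)cc2)cc1`, continues the same series: methoxy in place of methyl on an aromatic carbon. Among the compounds with values here, no measured step involves a methoxy group, so the closest guide is that three different groups at this position gave numbers that could not be told apart. A methoxy is one more change at the same place, and the expectation is a step of a 1.1-fold lower number from compound 3 to compound 4 (0.04 log units; within the scatter) that remains within the scatter. For compound 4 in this assay the estimate is 45000 nM, with a range from 20000 nM to 100000 nM.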

Compound 4, half-maximal inhibitory concentration: > 50000 nM
Compound 4: no number, only a limit; the forecaster's own chance of this, stated with the estimate: 20%; at least 1.1-fold (0.04 log units) between middle value and limit.
By their numbers in this assay, from the lowest: compounds 2, 1 and 3 (each within the scatter of the next). At a limit, above all of these: compound 4.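

In this assay compound 4 gives > 50000 nM as a limit of the assay and not as a number, the first such result among the groups shown at this position. The step of an at least 1.0-fold higher number from compound 3 to compound 4 (0.00 log units; that floor lies within the scatter) is therefore only a floor, as are the step of an at least 1.1-fold higher number from compound 2 to compound 4 (0.07 log units; that floor lies within the scatter) and the step of an at least 1.1-fold higher number from compound 1 to compound 4 (0.04 log units; that floor lies within the scatter) from the two halogen compounds. Within the data shown here, compound 4 thus cannot be placed in order with compounds 1, 2 and 3: it may sit with them or well beyond them, so methoxy, the first group here to bring in an oxygen, neither confirms nor breaks the flat picture.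

From the compounds shown here alone, whether any group at this position can move the number beyond the scatter, in either direction, stays open. An amine, a carboxylic acid or a longer chain in place of the methoxy would be a further test of that question.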